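Swapping One Group in a Growth Inhibitor

A few compounds are considered here, and "the series" means these few. Any claim that something is new, unique, unknown or untested is made for them only; others in the source may bear on it.

For the measured compounds named here, compound 1 `CC(=O)N1CCN(c2ccc(Nc3nccc(-c4c[nH]c5cccnc45)n3)cc2)CC1` gives 420 nM in a functional assay on MV4-11 cells (Homo sapiens) for antiproliferative activity, read by resazurin assay, with a stated time of 72 h (on this read-out higher numbers stand for weaker inhibition of growth and lower numbers for stronger inhibition of growth), and so holds the higher of the two numbers known so far, which means the weaker inhibition of growth. Compound 2 `CC(=O)N1CCCN(c2cccc(Nc3nccc(-c4cnc5n(C)cccc4-5)n3)c2)CC1` gives 24 nM in this assay and sits lower by a gap beyond the scatter.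

Compound 3 `CC(=O)N1CCN(c2ccc(Nc3nccc(-c4n[nH]c5ccccc45)n3)cc2)CC1` has not been measured yet. It has the same atoms as compound 1, joined differently: a group of 9 heavy atoms (7 carbon, 2 nitrogen; one five-membered aromatic ring with 2 hetero atoms, one six-membered aromatic ring of carbon only) in place of a group of 9 heavy atoms (7 carbon, 2 nitrogen; one five-membered aromatic ring with 1 hetero atom, one six-membered aromatic ring with 1 hetero atom), on an aromatic carbon and the 1H-indazol-3-yl group enters on an aromatic carbon of the six-membered aromatic ring with 2 nitrogen.

Going by the values given here, no measured pair shows this swap, so compound 1 at 420 nM is the only anchor for an expectation. The estimated step of a 1.2-fold higher number from compound 1 to compound 3 (0.08 log units; within the scatter) is small, and no shift beyond the scatter is expected in either direction. In this assay the estimated value for compound 3 is 500 nM with an expected range of 130 nM to 1900 nM until a measurement arrives.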

Compound 3, concentration for 50% growth inhibition: 346 nM
Beside the measured number, compound 3's estimate is 1.4-fold (0.16 log units) above it; the range from low to high includes it.
By their numbers in this assay, from the lowest: compound 2; then compounds 3 and 1 (each within the scatter of the next).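

The first swap measured at this aromatic carbon of the six-membered aromatic ring with 2 nitrogen, read in this assay, gives a 1.2-fold lower number from compound 1 to compound 3 (0.08 log units; within the scatter) on the shared core. One ring nitrogen of the leaving group is thus replaced by a second nitrogen in the five-membered ring of 1H-indazol-3-yl, with the heavy-atom, donor and acceptor counts unchanged, and the read-out cannot tell the two compounds apart. Nothing available here explains this match between the two groups.

On these data alone, whether a plain phenyl ring, or a ring carrying an amine or a carboxylic acid, would hold the same level of growth inhibition at this carbon stays open. Also open, as far as these compounds go, is whether this swap would give a similar result with a different group in place of the acetyl piperazine on the other side of the molecule.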